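The compounds below may be only part of what the source reports. "The series", "measured", "known", "first", "only" and "open" are said of these compounds alone.

Of the compounds shown here, three built on one shared core have been tested in a functional assay on the whole organism (strain albino) with Mus musculus as the target, in the maximal electroshock model, with a stated time of 4 h; a lower number here means that less compound is needed, a higher number that more compound is needed for the effect. Compound 1 `Cc1ccccc1Nc1nnc(Nc2nc(-c3ccc(Cl)cc3)cs2)s1` gives 300 mg/kg in this assay. Compound 2 `Cc1ccc(Nc2nnc(Nc3nc(-c4ccc(Cl)cc4)cs3)s2)cc1` differs from compound 1 only in one change, (4-methylphenyl in place of 2-methylphenyl on a nitrogen on an aromatic ring), and in this assay compound 2 gives 100 mg/kg, which is a step of a 3.0-fold lower number from compound 1 to compound 2 (0.48 log units; beyond the scatter). Compound 3 `Cc1ccccc1Nc1nnc(Nc2nc(-c3ccc([N+](=O)[O-])cc3)cs2)s1` keeps the 2-methylphenyl of compound 1 but carries a different core; the difference between the two cores is nitro in place of chloro on an aromatic carbon. In this assay compound 3 gives 100 mg/kg, a step of a 3.0-fold lower number from compound 1 to compound 3 (0.48 log units; beyond the scatter). The numbers for compound 2 and compound 3 stand level at the digits reported.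

Compound 4 `Cc1ccc(Nc2nnc(Nc3nc(-c4ccc([N+](=O)[O-])cc4)cs3)s2)cc1` has not yet been measured. It differs from compound 3 by 4-methylphenyl in place of 2-methylphenyl on a nitrogen on an aromatic ring, and this is the same change that separates compound 1 from compound 2, now made on the core of compound 3 rather than on the core of compound 1. Within the data shown here, for compound 4 the expectation is a step of about a 2.0-fold lower number from compound 3 to compound 4 (0.30 log units; within the scatter) in this assay, resting on the single earlier example of this change, the step of a 3.0-fold lower number from compound 1 to compound 2 (0.48 log units; beyond the scatter), and on the value of compound 3, 100 mg/kg. That step was seen only once and on a different core. The estimate is kept somewhat cautious. Compound 4 is therefore expected to give about 50 mg/kg in this assay, with a plausible range from 25 mg/kg to 100 mg/kg.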

Compound 4, minimum effective dose: 100 mg/kg
Compound 4: middle estimate off by 2.0-fold (0.30 log units), on the low side; the range from low to high includes it.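

In this assay, the change from 2-methylphenyl to 4-methylphenyl, which lowered the number on the core of compound 1, gives no change at the digits printed from compound 3 to compound 4 (within the scatter) on the core of compound 3, so the step did not carry over from one core to the other: the same change on two cores in this assay, a 3.0-fold lower number (0.48 log units; beyond the scatter) from compound 1 to compound 2 and no change at the digits printed (within the scatter) from compound 3 to compound 4, 3.0-fold (0.48 log units) apart, beyond the scatter of two such steps

The nitro in place of chloro change behaves likewise, giving no change at the digits printed from compound 2 to compound 4 (within the scatter) with the 4-methylphenyl group present, whereas it lowered the number with the 2-methylphenyl group present: the same change on two cores in this assay, a 3.0-fold lower number (0.48 log units; beyond the scatter) from compound 1 to compound 3 and no change at the digits printed (within the scatter) from compound 2 to compound 4, 3.0-fold (0.48 log units) apart, beyond the scatter of two such steps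

Both comparisons rest on the same four compounds, in which compound 1 alone stands apart while compound 2, compound 3 and compound 4 are level at the digits printed, so they show that the two changes do not add up here but not why, nor how either change would behave on any further core.

The compounds shown leave open whether a methoxy group or a fluorine atom in place of the methyl on the phenyl ring would shift the number in this assay. They also leave open whether a nitrile or an amine in place of the nitro or chloro group would bring the number below the level shared by these three compounds.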